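The source may report more compounds than this note shows. Statements on the series, on what has been measured and on what is new or still open speak of the compounds shown alone.

Of the compounds shown here, three sharing one core have been tested in a functional assay on A549 cells (Homo sapiens) for cytotoxicity, read by MTT assay, with a stated time of 24 h; on this read-out higher numbers stand for weaker inhibition and lower numbers for stronger inhibition. Compound 1 `O=c1nc2ccc(Br)cn2cc1Cc1ccc(Br)cc1` gives 102000 nM, and compound 3 `O=c1nc2ccc(Br)cn2cc1Cc1ccc(Cl)cc1` gives 105000 nM. Compound 2 `COc1ccc(Cc2cn3cc(Br)ccc3nc2=O)cc1` returns only a limit of the assay, > 1000000 nM, and not a true number.

Compound 3 therefore stands level with compound 1, with a 1.0-fold higher number from compound 1 to compound 3 (0.01 log units; within the scatter), and clearly apart from compound 2, with an at least 9.5-fold lower number from compound 2 to compound 3 (0.97 log units; beyond the scatter).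

Compound 4 `O=c1nc2ccc(Br)cn2cc1Cc1ccccc1` has not yet been measured. It drops the chloro of compound 3: hydrogen in place of chloro on an aromatic carbon. This puts hydrogen in place of chloro on an aromatic carbon, para to a large group.

Two measured steps at this same place bear on the change. Swapping one halogen for the other made no difference beyond the scatter, as a 1.0-fold higher number from compound 1 to compound 3 (0.01 log units; within the scatter) shows. Compound 2 shows that the place still matters, with an at least 9.8-fold higher number from compound 1 to compound 2 (0.99 log units; beyond the scatter). Hydrogen is neither a halogen nor methoxy, so these steps frame the question without settling it. A small move towards weaker inhibition seems the likeliest outcome, far short of the methoxy step. The expected step is a 1.6-fold higher number from compound 3 to compound 4 (0.21 log units; within the scatter). The estimate for compound 4 is 170000 nM, with an expected range from 70000 nM to 500000 nM.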

Compound 4, half-maximal inhibitory concentration: > 1000000 nM
Compound 4 was reported as a limit; the forecaster's own chance of this, stated with the estimate: 12%; at least 5.8-fold (0.76 log units) between middle value and limit.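

The earlier compounds shown here showed that chloro and bromo are interchangeable at this place, but not whether a halogen is needed there at all. Replacing the halogen with hydrogen is no small change: in this assay there is an at least 9.5-fold higher number from compound 3 to compound 4 (0.97 log units; beyond the scatter), and there is also an at least 9.8-fold higher number from compound 1 to compound 4 (0.99 log units; beyond the scatter). Among the compounds shown, only the two carrying a halogen at this place give a true number, while compound 2 with methoxy and compound 4 with hydrogen each return only a limit of the assay, and the step between those two cannot be read: the limit of > 1000000 nM in this assay, at which 2 of the 4 values shown sit.

Going by these compounds, it remains open whether fluoro would behave like chloro and bromo, and whether a methyl or a nitrile at the same place could keep the number close to that of compound 3. An amine or a carboxylic acid here would further test whether anything other than a halogen can give a true number at this place.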